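This account rests on a few compounds, and the source may have more. Where it says the series, first, only, none or still open, it means among the compounds named here.

Of the compounds shown here, three sharing one core have been tested in a functional assay on MCF7 cells (Homo sapiens) for inhibition, read by MTT assay, with a stated time of 24 h; on this read-out higher numbers stand for weaker inhibition and lower numbers for stronger inhibition. There, compound 1 `Cc1cccc(C)c1/C=C/[C@@H]1CCCCN1` gives 4.29 ug/mL, compound 3 `COc1ccccc1/C=C/[C@@H]1CCCCN1` gives 3.81 ug/mL, and compound 2 `O=[N+]([O-])c1ccc(/C=C/[C@@H]2CCCCN2)cc1` gives 2.15 ug/mL. Compound 2 holds the lowest of these three numbers, but its gaps to compound 3 and compound 1 both lie within the usual scatter of repeated measurements, so the data do not separate the three.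

A fourth compound, compound 4 `COc1ccc(/C=C/[C@@H]2CCCCN2)cc1`, has not yet been measured. It keeps the core of compound 2 and changes one group: methoxy in place of nitro on an aromatic carbon. In words, methoxy stands in place of nitro on an aromatic carbon.

Among the compounds with values here, no two tested compounds differ in just one place, so the data offer no direct measure of what such a swap does. The closest guide is compound 3, which also carries a methoxy group and gives 3.81 ug/mL. This suggests a small move toward a higher number in this assay, which would mean somewhat weaker inhibition, though probably nothing beyond the scatter. The expected size of the step of a 1.6-fold higher number from compound 2 to compound 4 (0.20 log units; within the scatter) reflects this modest shift. For compound 4, the estimated value is 3.4 ug/mL, with an expected range from 1.5 ug/mL to 7.5 ug/mL.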

Compound 4, half-maximal inhibitory concentration: 3.57 ug/mL
The estimate for compound 4 lay 1.1-fold (0.02 log units) below the measured number, within the range that was stated.
By their numbers in this assay, from the lowest: compounds 2, 4, 3 and 1 (each within the scatter of the next).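

In this assay, within the data shown here, the exchange of nitro for methoxy on an aromatic carbon, para to a group of 8 heavy atoms, provides the first comparison in which only one place differs: a 1.7-fold higher number from compound 2 to compound 4 (0.22 log units; within the scatter). This step lies within the usual scatter of repeated measurements, so the assay does not separate these two groups at this position, even though nitro brings nitrogen and oxygen atoms while methoxy brings carbon and oxygen atoms. No measurement available here helps to explain this result.

The compounds shown cover only this single exchange, so it remains open whether an amine, a carboxylic acid or a longer chain such as butoxy on the same aromatic carbon would give a step beyond the scatter. Going by these compounds, it also remains open whether the result from this pair would hold on a different shared core or in another assay, since one pair of compounds cannot establish a general pattern for nitro and methoxy.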